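Cytotoxicity of a Chloro-Fluoro Analogue on Vero Cells

The compounds below may be only part of what the source reports. "The series", "measured", "known", "first", "only" and "open" are said of these compounds alone.

Compound 1 `C[C@]1(CN2CCc3nc(-c4ccccc4F)ccc3C2)Cn2cc([N+](=O)[O-])nc2O1`: > 32 ug/mL in an ADME assay on Vero cells (Chlorocebus sabaeus) for cytotoxicity, read by MTT assay, with a stated time of 72 h; a lower number here means that less compound is tolerated, a higher number that more compound is tolerated
Compound 2 `C[C@]1(CN2CCc3nc(-c4ccc(C#N)cc4)ccc3C2)Cn2cc([N+](=O)[O-])nc2O1`: "not determined" (no result reported) in this assay
Compound 3 `C[C@]1(CN2CCc3nc(-c4cccc(F)c4F)ccc3C2)Cn2cc([N+](=O)[O-])nc2O1`: > 32 ug/mL in this assay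

Compound 3 stands at a limit of this assay rather than at a number. Compound 1 likewise sits at a limit of this assay. For compound 2 no result was reported. The step that the two limits leave unreadable from compound 1 to compound 3 cannot be read from the two limits; what is shown is the limit of > 32 ug/mL in this assay, at which 2 of the 3 values shown sit. Compound 4 `C[C@]1(CN2CCc3nc(-c4cc(F)ccc4Cl)ccc3C2)Cn2cc([N+](=O)[O-])nc2O1` differs from compound 3 by 2-chloro-5-fluorophenyl in place of 2,3-difluorophenyl on an aromatic carbon. Among the measured compounds shown here, no measured step bears on this change, since the one measured step is unreadable. Compound 4 is therefore expected to sit at or near the same limit, with an expected step of a number no higher from compound 3 to compound 4 (the limit leaves the size open), giving an estimate of 32 ug/mL with a range from 16 ug/mL to 64 ug/mL.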

Compound 4, half-maximal cytotoxic concentration: > 32 ug/mL
Compound 4: no number, only a limit (the forecaster's own chance of this, stated with the estimate: 80%); the middle value lies on the limit itself.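

Compound 4 also sits at a limit in this assay, so its steps from compound 1 and compound 3 cannot be read: the limit of > 32 ug/mL in this assay, at which 3 of the 4 values shown sit. The compounds shown leave open where the true cytotoxic concentrations of these three compounds lie, and whether the ring changes shift them at all.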